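A ring-bearing group replaces an open one in compound 2

The source may hold more compounds than are shown below. What is called first, only, known or untested is meant among the compounds shown, and "the series" means these compounds.

Compound 1 `CN(C(=O)OCc1c(-c2ccc(O[C@H]3CCC[C@H](C(=O)O)C3)cc2)cnn1C)C1CCCC1` gives 0.009
Compound 2 `Cc1noc(-c2ccc(O[C@H]3CCC[C@H](C(=O)O)C3)cc2)c1CNC(=O)OCCC(C)(C)C` gives 0.006

In an ADME assay on the whole organism (plasma, Homo sapiens) for protein binding, read by LC-MS, with a stated time of 24 h (a higher number here means a larger unbound share of the compound, a lower number a smaller unbound share), compound 2 gives 0.006 and stands within the scatter of compound 1 at 0.009, so these two cannot be ranked. Compound 3 `Cc1noc(-c2ccc(O[C@H]3CCC[C@H](C(=O)O)C3)cc2)c1COC(=O)N(C)C1CCCC1` is still unmeasured and differs from compound 2 by a single change, (a group of 10 heavy atoms (7 carbon, 1 nitrogen, 2 oxygen; one five-membered non-aromatic ring of carbon only) in place of a group of 10 heavy atoms (7 carbon, 1 nitrogen, 2 oxygen; no ring), on a saturated chain carbon bound to an aromatic carbon). Among the compounds with values here, no measured pair shows what this change does. Compound 1 at 0.009 also carries a five-membered non-aromatic ring of carbon only, though on a different core. A shift no larger than the scatter is therefore expected in this assay, with the estimated step being a 1.3-fold higher number from compound 2 to compound 3 (0.12 log units; within the scatter). Compound 3 is estimated at 0.008, with an expected range from 0.004 to 0.015.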

Compound 3, unbound fraction: 0.004
For compound 3 the middle estimate is 2.0-fold (0.30 log units) above the measured one, and the stated range covers the measured number.
By their numbers in this assay, from the lowest: compounds 3, 2 and 1 (each within the scatter of the next, the first and the last beyond it).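

In this assay the swap gives a 1.5-fold lower number from compound 2 to compound 3 (0.18 log units; within the scatter) and so, at this saturated chain carbon bound to an aromatic carbon, the open group and the group with the five-membered carbon ring cannot be told apart. This holds although the entering group has 0 hydrogen-bond donors and the leaving group has 1. Nothing shown gives a reason for the result.

From the compounds shown here alone, whether an amine or a longer chain at this place would shift the unbound fraction beyond the scatter stays open. So does the effect of this swap on the core of compound 1.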